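Notes on an ethyl to methyl step

The compounds below may be only part of what the source reports. "The series", "measured", "known", "first", "only" and "open" are said of these compounds alone.

Measured in a functional assay on K562 cells (Homo sapiens) for cytotoxicity, with a stated time of 72 h; on this read-out higher numbers stand for weaker inhibition and lower numbers for stronger inhibition
Compound 1 (`Cc1cccc(-c2nn3c(c2-c2ccnc(Nc4ccc(S(N)(=O)=O)cc4)c2)C(C)C(C)(C)C3)n1`) gives 31000 nM
Compound 2 (`CCc1cccc(-c2nn3c(c2-c2ccncc2)C(C)C(C)(C)C3)n1`) gives > 100000 nM, a limit and not a number

Compound 2 stands only at the limit of this assay, which is the limit of > 100000 nM in this assay, at which 1 of the 2 values shown sits. Compound 3 (`Cc1cccc(-c2nn3c(c2-c2ccncc2)C(C)C(C)(C)C3)n1`) differs from compound 2 by hydrogen in place of methyl on a saturated chain carbon bound to an aromatic carbon, with hydrogen in place of methyl on a saturated chain carbon bound to an aromatic carbon, so that 6-ethylpyridin-2-yl becomes 6-methylpyridin-2-yl. Within the data shown here, no measured pair shows this change. No shift beyond the scatter is expected in this assay, and the expected size is the estimated step of a number no higher from compound 2 to compound 3 (the limit leaves the size open). This expectation rests on compound 2 and its limit (> 100000 nM). For compound 3 the estimate is 100000 nM (range 40000 nM to 200000 nM).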

Compound 3, half-maximal inhibitory concentration: > 100000 nM
Compound 3: only a limit was reported; the forecaster's own chance of this, stated with the estimate: 75%; the middle value lies on the limit itself.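

Compound 3 also returns only a limit in this assay, and the ethyl to methyl step cannot be read because both of its compounds rest on that limit: the limit of > 100000 nM in this assay, at which 2 of the 3 values shown sit.

The readable comparison lies at another place: hydrogen in place of (4-sulfamoylphenyl)amino on an aromatic carbon gives an at least 3.2-fold higher number from compound 1 to compound 3 (0.50 log units; beyond the scatter). Of the three compounds, only compound 1 carries a number rather than a limit.

Going by these compounds, whether 6-ethylpyridin-2-yl and 6-methylpyridin-2-yl differ at all stays open. Also open, on these data alone, is how a simple amine or a carboxylic acid on that aromatic carbon would compare with (4-sulfamoylphenyl)amino.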